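Swapping the ether side chain for a bicyclic amine

A few compounds are considered here, and "the series" means these few. Any claim that something is new, unique, unknown or untested is made for them only; others in the source may bear on it.

Measured so far:
- compound 1 `O=C(c1cc2cc(C3CC3)ccc2[nH]1)N1CC(=O)N(Cc2ccccc2)[C@@H](CN2CCC(F)CC2)C1`: 24500 nM
- compound 2 `COc1cccc(CN2C(=O)CN(C(=O)c3cc4cc(OC)ccc4[nH]3)C[C@@H]2c2ccccc2)c1`: > 10000 nM
- compound 3 `COc1ccc2[nH]c(C(=O)N3CC(=O)N(Cc4ccccc4)[C@@H](COC(C)(C)C)C3)cc2c1`: 78200 nM

All three share a core in which an indole amide is joined to a lactam ring carrying a benzyl group, and they differ in the side chain on that ring. In an ADME assay on Vero cells (Chlorocebus sabaeus) for cytotoxicity, with a stated time of 7 days (on this read-out lower numbers stand for higher toxicity in this test and higher numbers for lower toxicity in this test), compound 3 gives 78200 nM, the highest of the two numbers obtained, so it is the least toxic of the pair. Compound 1 gives 24500 nM, a lower number that lies beyond the scatter. For compound 2 the result is only a limit, (the limit of > 10000 nM in this assay, at which 1 of the 3 values shown sits), and no number is known.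

Compound 4 `COc1ccc2[nH]c(C(=O)N3CC(=O)N(Cc4ccccc4)[C@@H](CN4CC5CCCCC5C4)C3)cc2c1` is the next compound. It differs from compound 3 by a group of 9 heavy atoms (8 carbon, 1 nitrogen; one five-membered non-aromatic ring with 1 hetero atom, one six-membered non-aromatic ring of carbon only) in place of a group of 5 heavy atoms (4 carbon, 1 oxygen; no ring), on a saturated chain carbon bound to a saturated ring carbon. Going by the values given here, compound 1 carries an amine-bearing chain at the same place, and its value of 24500 nM sits below that of compound 3, which is the only guide here. Compound 4 is therefore expected to move in the same direction, a moderate step downward beyond the scatter, a 3.6-fold lower number from compound 3 to compound 4 (0.55 log units; beyond the scatter). The estimated value for compound 4 is 22000 nM, with a range from 7000 nM to 65000 nM.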

Compound 4, half-maximal cytotoxic concentration: 8200 nM
The estimate for compound 4 lay 2.7-fold (0.43 log units) above the measured number; low and high end bracket the measured number.
By their numbers in this assay, from the lowest: compound 4; then compound 1; then compound 3.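

In this assay, going by these compounds alone, putting the bicyclic amine in place of the tert-butoxy group gives a 9.5-fold lower number from compound 3 to compound 4 (0.98 log units; beyond the scatter), which is the first step in this set where only one part of the molecule changes. Within the data shown here, it shows that the group on this saturated chain carbon bound to a saturated ring carbon can, on its own, shift the cytotoxicity number beyond the scatter, towards higher toxicity in this test, whereas the earlier compounds differ in more than one place and could not isolate such an effect. The data shown offer no measured property that explains the size or direction of this step.

The entering group brings in a nitrogen and two rings together, so this single step cannot tell which of these features goes with the lower number, and an open-chain amine such as diethylamino on the same carbon would help to separate them. On these data alone, it also remains open whether a similar step would appear with a different group on the indole, such as the cyclopropyl group of compound 1.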